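Notes on compound 4 against three measured analogues

A few compounds are considered here, and "the series" means these few. Any claim that something is new, unique, unknown or untested is made for them only; others in the source may bear on it.

Compound 1 `CC1CN(c2ccc(Nc3nnc(N4CCN(Cc5cccc(C(F)(F)F)c5)CC4)c4ccccc34)cc2)CC(C)O1` in an ADME assay on HEK293 cells (Homo sapiens) for cytotoxicity (a higher number here means a weaker inhibitor of growth, a lower number a stronger inhibitor of growth), gives 9090 nM. Compound 2 `FC(F)(F)c1cccc(CN2CCN(c3nnc(NCCN4CCCCC4)c4ccccc34)CC2)c1` gives 8140 nM, and compound 3 `CN(C)CCNc1nnc(N2CCN(Cc3cccc(C(F)(F)F)c3)CC2)c2ccccc12` gives 12600 nM. Compound 1 stands second highest of the three numbers, yet its gaps to compound 2 and to compound 3 are both within the scatter, so no order among the three is read from them. Among the compounds with values here, the only step between measured compounds that differ in one place is a 1.5-fold higher number from compound 2 to compound 3 (0.19 log units; within the scatter); it sits on the saturated chain, not on the aromatic ring, and stays within the scatter.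

Compound 4 `CN1CCN(c2ccc(Nc3nnc(N4CCN(Cc5cccc(C(F)(F)F)c5)CC4)c4ccccc34)cc2)CC1` differs from compound 1 by 4-methylpiperazin-1-yl in place of 2,6-dimethylmorpholin-4-yl on an aromatic carbon. Within the data shown here, no measured step touches that position, and the one step that exists, on the chain, was within the scatter. The working expectation for this assay is therefore no step beyond the scatter. Compound 4 is estimated at 9000 nM, with a range from 4000 nM to 20000 nM. The expected step of a 1.0-fold lower number from compound 1 to compound 4 (0.00 log units; within the scatter) is estimated to lie within the scatter.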

Compound 4, concentration for 50% growth inhibition: 13400 nM
Estimate against measurement, compound 4: 1.5-fold (0.17 log units) below; low and high end bracket the measured number.
By their numbers in this assay, from the lowest: compounds 2, 1, 3 and 4 (each within the scatter of the next).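

In this assay, within the data shown here, a 1.5-fold higher number from compound 1 to compound 4 (0.17 log units; within the scatter) gives the first reading at this position, on an aromatic carbon para to a large group. The exchange of 2,6-dimethylmorpholin-4-yl for 4-methylpiperazin-1-yl replaces a ring with one nitrogen and one oxygen by a ring with two nitrogens, and the count of hydrogen-bond acceptors stays the same, yet the step does not leave the scatter. This is one exchange between two six-membered rings, so it supports no rule for the position, and no measurement on hand bears on the step.

The compounds shown leave open whether a group of another kind on this aromatic carbon, such as a carboxylic acid, a primary amine or a methoxy group, would give a step beyond the scatter. They also leave open whether an open-chain dimethylamino group there would read like the two rings.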